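Chloro in place of hydrogen: expecting a small step

A few compounds are considered here, and "the series" means these few. Any claim that something is new, unique, unknown or untested is made for them only; others in the source may bear on it.

- compound 1 `CCOc1ccc(-c2ccc3ncn(-c4cc(OC)c(OC)c(OC)c4)c3c2)cc1`: 1710 nM
- compound 2 `COc1cc(-n2cnc3ccc(-c4ccccc4)cc32)cc(OC)c1OC`: 2290 nM

Going by the values given here, in a functional assay on MCF7 cells (Homo sapiens) for antiproliferative activity, read by MTT assay, with a stated time of 72 h (on this read-out lower numbers stand for stronger inhibition and higher numbers for weaker inhibition), compound 2 stands within the scatter of compound 1, the only other measured compound. Compound 3 `COc1cc(-n2cnc3ccc(-c4cccc(Cl)c4)cc32)cc(OC)c1OC` differs from compound 2 by chloro in place of hydrogen on an aromatic carbon. Among the compounds with values here, one measured step bears on this: a 1.3-fold higher number from compound 1 to compound 2 (0.13 log units; within the scatter), hydrogen in place of ethoxy on an aromatic carbon. Within the data shown here, no chloro compound has been measured, so nothing beyond the scatter is expected, in either direction. The expected change is a 1.2-fold lower number from compound 2 to compound 3 (0.08 log units; within the scatter). For compound 3 the estimated value is 1900 nM, with an expected range of 700 nM to 5000 nM.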

Compound 3, half-maximal inhibitory concentration: 3120 nM
Beside the measured number, compound 3's estimate is 1.6-fold (0.22 log units) below it; measured number inside the range.
By their numbers in this assay, from the lowest: compounds 1, 2 and 3 (each within the scatter of the next).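

In this assay, chloro on an aromatic carbon, meta to a large group, gives a 1.4-fold higher number from compound 2 to compound 3 (0.13 log units; within the scatter) and so adds no step beyond the scatter at this position. Taken with the ethoxy result, 3-chlorophenyl in place of 4-ethoxyphenyl gives a 1.8-fold higher number from compound 1 to compound 3 (0.26 log units; within the scatter) and likewise stays within the scatter, so the hydrogen, chloro and ethoxy compounds are not told apart here. Nothing at hand accounts for these small steps. On these data alone, whether an amine or a carboxylic acid on this ring would move the number beyond the scatter remains open.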